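The source may hold more compounds than are shown below. What is called first, only, known or untested is meant among the compounds shown, and "the series" means these compounds.

Measured in a functional assay on HeLa cells (Homo sapiens) for cytotoxicity, read by MTT assay, with a stated time of 24 h; on this read-out lower numbers stand for stronger inhibition and higher numbers for weaker inhibition:
- compound 1 `CCCCCCCCCC(=O)Nc1nnc(S[C@@H]2O[C@H](CO)[C@H](O)[C@H](O)[C@H]2O)s1`: 25900 nM
- compound 2 `CCCCCCCC/C=C\CCCCCCCCCCCC(=O)Nc1nnc(S[C@@H]2O[C@H](COC(C)=O)[C@H](OC(C)=O)[C@H](OC(C)=O)[C@H]2OC(C)=O)s1`: 58500 nM
- compound 3 `CCCCCCCCCCCCCCCCCC(=O)Nc1nnc(S[C@@H]2O[C@H](COC(C)=O)[C@H](OC(C)=O)[C@H](OC(C)=O)[C@H]2OC(C)=O)s1`: 97500 nM

Compound 1 has the lowest number of the three, and the numbers of compound 2 and compound 3 both lie above it by more than the scatter. Compound 4 `CCCCCCCCCCCC(=O)Nc1nnc(S[C@@H]2O[C@H](CO)[C@H](O)[C@H](O)[C@H]2O)s1` has not yet been measured. It carries ethyl in place of hydrogen on a saturated chain carbon, nine bonds along the chain from a carbonyl carbon; counted in full, the change is ethyl in place of hydrogen on a saturated chain carbon, nine bonds along the chain from a carbonyl carbon.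

For the measured compounds named here, no measured step starts from compound 1. Going by the values given here, the one measured step that alters a chain is a 1.7-fold higher number from compound 2 to compound 3 (0.22 log units; within the scatter). It bears on this change only loosely: compound 2 and compound 3 also differ from compound 1 outside the chain. A shift beyond the scatter is therefore not expected in this assay, and the data favour no direction. The expected result is a 1.0-fold higher number from compound 1 to compound 4 (0.02 log units; within the scatter). For compound 4 the estimate is 27000 nM, with an expected range from 12000 nM to 60000 nM.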

Compound 4, half-maximal inhibitory concentration: 8700 nM
The estimate for compound 4 lay 3.1-fold (0.49 log units) above the measured number, outside the stated range (below it).
By their numbers in this assay, from the lowest: compound 4; then compound 1; then compounds 2 and 3 (each within the scatter of the next).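

In this assay, ethyl in place of hydrogen on a saturated chain carbon, nine bonds along the chain from a carbonyl carbon, gives a real shift (a 3.0-fold lower number from compound 1 to compound 4 (0.47 log units; beyond the scatter)). For the compounds shown here, the only chain step seen before (a 1.7-fold higher number from compound 2 to compound 3 (0.22 log units; within the scatter)) stayed within the scatter, and it lay on a different part of the chain in compounds that also differ from compound 1 outside the chain. This result therefore shows that, on the core of compound 1, extending the chain at this position can move the cytotoxicity read-out beyond the scatter. Nothing measured here explains the shift.

The compounds shown leave open whether a longer chain on the core of compound 1 would lower the number further or reverse the step. They also leave open whether an amine or a carboxylic acid at the end of the chain would keep the lower number of compound 4.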